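This account rests on a few compounds, and the source may have more. Where it says the series, first, only, none or still open, it means among the compounds named here.

Of the compounds shown here, three built on one shared core have been measured in an ADME assay (liver) for pharmacokinetics, with Liver microsome (Rattus norvegicus) as the target, using microsomes; on this read-out higher numbers stand for a longer-lived compound and lower numbers for a shorter-lived compound. Compound 1 `CCCCCCOC(=O)/C=C/c1ccc(NC(=O)C2(NC(=O)c3ccc4c(C5CCCC5)c(-c5ncc(Cl)cn5)n(C)c4c3)CCC2)cc1OCC` gives 12.7 h. Compound 2 `CCOc1cc(NC(=O)C2(NC(=O)c3ccc4c(C5CCCC5)c(-c5ncc(Cl)cn5)n(C)c4c3)CCC2)ccc1/C=C/C(=O)OCCOCCOC` gives 1.07 h, and compound 3 `CCOc1cc(NC(=O)C2(NC(=O)c3ccc4c(C5CCCC5)c(-c5ncc(Cl)cn5)n(C)c4c3)CCC2)ccc1/C=C/C(=O)OCC(N)=O` gives 0.383 h, the lowest of the three. Compound 4 `CCOc1cc(NC(=O)C2(NC(=O)c3ccc4c(C5CCCC5)c(-c5ncc(Cl)cn5)n(C)c4c3)CCC2)ccc1/C=C/C(=O)OCC(=O)N(C)C(C)C` differs from compound 3 by isopropyl(methyl)amino in place of amino on a carbonyl carbon. Every earlier step at this tail ran downward: a 12-fold lower number from compound 1 to compound 2 (1.07 log units; beyond the scatter), a 33-fold lower number from compound 1 to compound 3 (1.52 log units; beyond the scatter) and a 2.8-fold lower number from compound 2 to compound 3 (0.45 log units; beyond the scatter); compound 1 stood highest. Because compound 3 sits at the bottom with 0.383 h, and the change enlarges the tail again, a modest upward step is expected, a 2.6-fold higher number from compound 3 to compound 4 (0.42 log units; beyond the scatter). Compound 4 is therefore estimated to give about 1 h, within a range from 0.4 h to 2.5 h.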

Compound 4, half-life: 0.267 h
For compound 4 the middle estimate is 3.7-fold (0.57 log units) above the measured one; measured number below the stated range.
By their numbers in this assay, from the lowest: compounds 4 and 3 (each within the scatter of the next); then compound 2; then compound 1.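

Putting isopropyl(methyl)amino in place of amino on the carbonyl carbon gives a 1.4-fold lower number from compound 3 to compound 4 (0.16 log units; within the scatter) in this assay and so shows that this larger end group does not bring the half-life back up. The tail of compound 4 stays well short of the two longer-lived compounds, with a 4.0-fold lower number from compound 2 to compound 4 (0.60 log units; beyond the scatter) and a 48-fold lower number from compound 1 to compound 4 (1.68 log units; beyond the scatter) as the gaps that remain. Nothing measured here explains this result. Still open, going by these compounds, is how a ring amine such as morpholine on that carbonyl carbon would behave, and whether a longer carbon chain there would move the half-life towards that of compound 1.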